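The compounds below may be only part of what the source reports. "The series", "measured", "known", "first", "only" and "open" are said of these compounds alone.

Working notes on the series. The shared core of compound 1 `Nc1cc(N)c2nc(-c3ccccc3)c(Sc3ccc(F)cc3)nc2c1` carries a phenyl group and a (4-fluorophenyl)sulfanyl group. In a functional assay on HOP-92 cells (Homo sapiens) for inhibition, read by sulforhodamine B assay, with a stated time of 48 h (a lower number here means that less compound is tolerated, a higher number that more compound is tolerated), compound 1 gives only a limit, < 100000 nM, and not a number. Compound 2 `COc1cc(CNc2nc3cc(N)cc(N)c3nc2-c2ccccc2)cc(OC)c1OC` is a second member of the same series. In this assay compound 2 also gives a limit, < 50200 nM. Compound 3 `CCOC(=O)[C@H](CCC(=O)O)NC(=O)c1ccc(CNc2nc3cc(N)cc(N)c3nc2-c2ccccc2)cc1` completes the measured set. In this assay compound 3 gives a limit as well, < 100000 nM. Thus no compound of the series has a defined number so far; the limit of < 100000 nM in this assay, at which 2 of the 3 values shown sit, and the limit of < 50200 nM in this assay, at which 1 of the 3 values shown sits, are all that is recorded, and no step between two measured compounds can be stated, so nothing is yet known about how a change of the group on the core moves the read-out.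

Compound 4 `Nc1cc(N)c2nc(-c3ccccc3)c(NCc3ccc(F)cc3)nc2c1` is the next candidate. Its change from compound 1 is (4-fluorobenzyl)amino in place of (4-fluorophenyl)sulfanyl on an aromatic carbon. Within the data shown here, with no measured step available for comparison, the expectation for a step that the limit leaves unreadable from compound 1 to compound 4 is a step of no clear direction and nothing beyond the scatter, most likely ending again at a limit. Compound 4 is therefore expected at about 60000 nM in this assay, with a range from 15000 nM to 100000 nM.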

Compound 4, concentration lethal to 50% of the cells: < 100000 nM
Compound 4: no number, only a limit; the forecaster's own chance of this, stated with the estimate: 60%; the middle value lies beyond the limit too.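

In this assay compound 4 gives only a limit, < 100000 nM. Among these compounds, compound 1 also stands at a limit, so no step between compound 1 and compound 4 can be read. The compounds shown leave open how (4-fluorobenzyl)amino in place of (4-fluorophenyl)sulfanyl moves the read-out, and what defined value any compound of the series has in this assay.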